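This account rests on a few compounds, and the source may have more. Where it says the series, first, only, none or still open, it means among the compounds named here.

Three analogues of the shared core of compound 1, `COc1cccc(C2(CNC(=O)Nc3c(C(C)C)cccc3C(C)C)CCCC2)c1`, differ only in the group carried on the saturated ring carbon, and all three have been tested in an assay on microsomes for inhibition of acyl-CoA:cholesterol acyltransferase (Oryctolagus cuniculus); a higher number here means a weaker inhibitor, a lower number a stronger inhibitor. Compound 1 gives 13 nM. Compound 2, `CC(C)c1cccc(C(C)C)c1NC(=O)NCC1(c2cccc([N+](=O)[O-])c2)CCCC1`, gives 51 nM, and compound 3, `CC(C)c1cccc(C(C)C)c1NC(=O)NCC1(c2cccc(N(C)C)c2)CCCC1`, gives 33 nM. Within this set compound 3 sits second highest: its number lies within the scatter of compound 2, while against compound 1 the step of a 2.5-fold higher number from compound 1 to compound 3 (0.40 log units; beyond the scatter) is beyond the scatter, as is a 3.9-fold higher number from compound 1 to compound 2 (0.59 log units; beyond the scatter); the pair a 1.5-fold lower number from compound 2 to compound 3 (0.19 log units; within the scatter) stays within the scatter.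

Compound 4, `CC(C)c1cccc(C(C)C)c1NC(=O)NCC1(c2ccc(CO)cc2)CCCC1`, has not yet been measured. It differs from compound 3 in one place: 4-(hydroxymethyl)phenyl in place of 3-(dimethylamino)phenyl on a saturated ring carbon. Among the compounds with values here, none of the measured steps exchanges a whole phenyl group in this way; they only show that swapping the substituent on that ring moves this assay modestly, never by more than the step from compound 1 to compound 2. Compound 4 is therefore expected to land near compound 3, with a step of a 1.1-fold higher number from compound 3 to compound 4 (0.03 log units; within the scatter) that need not exceed the scatter. The estimate for compound 4 in this assay is 35 nM, with a range from 12 nM to 110 nM.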

Compound 4, half-maximal inhibitory concentration: 26 nM
Estimate against measurement, compound 4: 1.3-fold (0.13 log units) above, within the range that was stated.
By their numbers in this assay, from the lowest: compounds 1, 4, 3 and 2 (each within the scatter of the next, the first and the last beyond it).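

In this assay, placing 4-(hydroxymethyl)phenyl on the saturated ring carbon instead of 3-(dimethylamino)phenyl gives a small step (a 1.3-fold lower number from compound 3 to compound 4 (0.10 log units; within the scatter)), so a group with one hydrogen-bond donor, replacing one with none, stays within the scatter of compound 3. The comparisons with the other two groups read the same way (a 2.0-fold lower number from compound 2 to compound 4 (0.29 log units; within the scatter); a 2.0-fold higher number from compound 1 to compound 4 (0.30 log units; within the scatter)), which leaves compound 4 inseparable from all three earlier compounds, even though compound 1 and compound 2 are set apart from each other (a 3.9-fold higher number from compound 1 to compound 2 (0.59 log units; beyond the scatter)). Nothing measured here accounts for this outcome.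

Because the exchange alters both the substituent and its place on the phenyl ring, the compounds shown cannot separate these two changes, and a comparison with 3-(hydroxymethyl)phenyl or 4-methoxyphenyl on the same carbon would be needed to do so. Going by these compounds, it also remains open whether a carboxylic acid, a primary amine or a longer chain ending in a hydroxyl group on that phenyl ring would stay within the same narrow band of values.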